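A Methoxy Group Enters the Aromatic Ring of Compound 1

The source may report more compounds than this note shows. Statements on the series, on what has been measured and on what is new or still open speak of the compounds shown alone.

Measured so far, in a functional assay for binding affinity to Norepinephrine transporter (Rattus norvegicus), read by radioligand binding, in the presence of a further agent that is not named here; on this read-out lower numbers stand for stronger inhibition and higher numbers for weaker inhibition:
compound 1, `C1=NCC(CC2=Cc3ccccc3CC2)N1`, gives 50.1 nM
compound 2, `Fc1cccc2c1C=C(CC1CN=CN1)CC2`, gives 126 nM
compound 3, `Cc1cccc2c1C=C(CC1CN=CN1)CC2`, gives 1000 nM

Compound 1 stands lowest of the three numbers in this assay. Its nearest neighbour is compound 2, reached by a 2.5-fold higher number from compound 1 to compound 2 (0.40 log units; beyond the scatter); its furthest is compound 3, reached by a 20-fold higher number from compound 1 to compound 3 (1.30 log units; beyond the scatter). Between the two substituted compounds lies a 7.9-fold higher number from compound 2 to compound 3 (0.90 log units; beyond the scatter).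

Compound 4, `COc1ccc2c(c1)C=C(CC1CN=CN1)CC2`, differs from compound 1 in one place: methoxy in place of hydrogen on an aromatic carbon. The two measured steps that bear on it both replace hydrogen on an aromatic carbon of the same core with a small group, and both raise the number, by a modest and by a large amount. A methoxy group has not been tried on this core, so the size remains uncertain, but a rise seems more likely than a fall. Compound 4 is therefore expected to give 160 nM in this assay, in a range from 40 nM to 650 nM. The expected step is a 3.2-fold higher number from compound 1 to compound 4 (0.50 log units; beyond the scatter).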

Compound 4, inhibition constant: < 1000 nM
Compound 4 was reported as a limit; the forecaster's own chance of this, stated with the estimate: 5%; the middle value lies beyond the limit too.
By their numbers in this assay, from the lowest: compound 1; then compound 2; then compound 3.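

The result for compound 4 is a limit and not a number, so no step from compound 1 to compound 4 can be read in this assay: the limit of < 1000 nM in this assay, at which 1 of the 4 values shown sits.

The compounds shown leave open whether methoxy in place of hydrogen on an aromatic carbon raises or lowers the number of compound 1, and by how much.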